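Swapping the Nitrogen Substituent on a Prostate Enzyme Inhibitor

A few compounds are considered here, and "the series" means these few. Any claim that something is new, unique, unknown or untested is made for them only; others in the source may bear on it.

Of the compounds shown here, three sharing one core have been measured in an assay on Prostate gland for inhibition of steroid 5-alpha-reductase (Rattus norvegicus); a higher number here means a weaker inhibitor, a lower number a stronger inhibitor. Compound 1 `CCCn1ccc2cc(/C(C)=C/C(=O)Nc3ccccc3OCCCC(=O)O)ccc21` carries a propyl group on the aromatic nitrogen and gives 190 nM. Compound 2 `CCCCC(CCCC)n1ccc2cc(/C(C)=C/C(=O)Nc3ccccc3OCCCC(=O)O)ccc21` gives 21 nM, and compound 3 `COc1ccc(Cn2ccc3cc(/C(C)=C/C(=O)Nc4ccccc4OCCCC(=O)O)ccc32)cc1` gives 480 nM. Compound 3 thus stands highest of the three: a 2.5-fold higher number from compound 1 to compound 3 (0.40 log units; beyond the scatter) and a 23-fold higher number from compound 2 to compound 3 (1.36 log units; beyond the scatter), while a 9.0-fold lower number from compound 1 to compound 2 (0.96 log units; beyond the scatter).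

Compound 4 `CCC(c1ccccc1)n1ccc2cc(/C(C)=C/C(=O)Nc3ccccc3OCCCC(=O)O)ccc21` is yet to be measured. It differs from compound 3 in one place: 1-phenylpropyl in place of 4-methoxybenzyl on an aromatic nitrogen. The two steps into compound 3 bear on this change: the 4-methoxybenzyl group of compound 3 gave the highest number on the nitrogen, and the branched 1-butylpentyl of compound 2 the lowest. The 1-phenylpropyl group is also branched and carries no methoxy group, so a lower number is expected for compound 4 in this assay, of a size between those two measured steps. The estimate for compound 4 is 90 nM, with a range from 25 nM to 350 nM. The estimated step is a 5.3-fold lower number from compound 3 to compound 4 (0.73 log units; beyond the scatter).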

Compound 4, half-maximal inhibitory concentration: 19 nM
Estimate against measurement, compound 4: 4.7-fold (0.68 log units) above, and the stated range ends above it.
By their numbers in this assay, from the lowest: compounds 4 and 2 (each within the scatter of the next); then compound 1; then compound 3.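

In this assay, 1-phenylpropyl in place of 4-methoxybenzyl on the aromatic nitrogen gives a 25-fold lower number from compound 3 to compound 4 (1.40 log units; beyond the scatter) even though both groups hold one six-membered aromatic ring, so carrying such a ring does not by itself set the number at this position. Phenyl in place of hydrogen on the saturated chain carbon bound to the aromatic nitrogen gives a 10-fold lower number from compound 1 to compound 4 (1.00 log units; beyond the scatter), showing that a ring placed there can go with a lower number, unlike the ring in compound 3. With a 1.1-fold lower number from compound 2 to compound 4 (0.04 log units; within the scatter) as the step between the two branched groups, 1-phenylpropyl and 1-butylpentyl cannot be told apart in this assay.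

No available evidence explains these differences.

Compound 3 differs from compound 4 in both branching and the methoxy group, so a plain benzyl group or a 1-(4-methoxyphenyl)propyl group would be needed to separate the two.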